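The source may hold more compounds than are shown below. What is called first, only, known or untested is meant among the compounds shown, and "the series" means these compounds.

Compound 3 `N#Cc1cccc(-c2c[nH]c3ncc(N4CCCCC4)cc23)c1`: 4000 nM
Compound 1 `Cn1cc(-c2cnc3[nH]cc(-c4ccc(F)c(C#N)c4)c3c2)cn1`: 4000 nM
Compound 2 `N#Cc1cccc(-c2c[nH]c3ncc(N4CCCC4)cc23)c1`: 300 nM

These three compounds have been measured in a physicochemical assay for solubility, read by LC-MS, in phosphate buffer, measured as thermodynamic solubility, with a stated time of 24 h, at pH 7.4; on this read-out higher numbers stand for higher solubility and lower numbers for lower solubility. Compound 3 stands level with compound 1 at the digits shown, the two together forming the top of the three numbers, while compound 2 lies well beneath them. Within the data shown here, the only measured step between two compounds that differ in a single place is a 13-fold higher number from compound 2 to compound 3 (1.12 log units; beyond the scatter), and it shows that swapping one ring for another on the same aromatic carbon can move the number a great deal.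

Compound 4 `Cn1cc(Nc2cnc3[nH]cc(-c4cccc(C#N)c4)c3c2)cn1` has not been measured. Its change from compound 3 is (1-methyl-1H-pyrazol-4-yl)amino in place of piperidin-1-yl on an aromatic carbon. Among the measured compounds shown here, no measured step covers this exchange directly: the step of a 13-fold higher number from compound 2 to compound 3 (1.12 log units; beyond the scatter) concerns two saturated rings of different size, not a switch to an aromatic ring joined through an amino group. Compound 1 carries the same 1-methylpyrazole ring on that carbon, without the amino link and with a further difference elsewhere, and its value is level with compound 3. The expectation for compound 4 is therefore a step of a 1.5-fold higher number from compound 3 to compound 4 (0.18 log units; within the scatter), within the scatter. Compound 4 is expected at 6000 nM, between 1500 nM and 25000 nM.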

Compound 4, solubility: 31000 nM
Estimate against measurement, compound 4: 5.2-fold (0.71 log units) below, and the stated range ends below it.
By their numbers in this assay, from the lowest: compound 2; then compounds 1 and 3 (each within the scatter of the next); then compound 4.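

In this assay, among these compounds, the earlier compounds showed only one saturated ring traded for another on this aromatic carbon, and the new result shows that a five-membered aromatic ring joined through an amino group can also raise the number. Putting (1-methyl-1H-pyrazol-4-yl)amino there produces a 7.8-fold higher number from compound 3 to compound 4 (0.89 log units; beyond the scatter) when it replaces piperidin-1-yl, and a 100-fold higher number from compound 2 to compound 4 (2.01 log units; beyond the scatter) when it replaces pyrrolidin-1-yl on the same carbon. No measurement available here gives a reason for either step.

On these data alone, the amino link and the pyrazole ring enter together, so the share of each in these steps stays open. Also open, as far as these compounds go, is what a morpholine ring or a simple dimethylamino group would give on this carbon.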